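The source may report more compounds than this note shows. Statements on the series, on what has been measured and on what is new or still open speak of the compounds shown alone.

Three close relatives of one shared core have been tested in a functional assay on cells (Platelet, Homo sapiens) for inhibition; on this read-out higher numbers stand for weaker inhibition and lower numbers for stronger inhibition. Compound 1 `CCOC(=O)c1ccc(-c2nn(Cc3ccccc3Cl)c3ccccc23)cc1` gives > 10000 nM, which is a limit of the assay rather than a number. Compound 2 `CCOC(=O)c1ccc(-c2nn(Cc3cccc(Cl)c3)c3ccccc23)cc1` gives > 10000 nM, again a limit. Compound 3 `CCOC(=O)c1ccc(-c2nn(Cc3ccccc3F)c3ccccc23)cc1` gives > 10000 nM, also a limit. Because (the limit of > 10000 nM in this assay, at which 3 of the 3 values shown sit), none of the steps among them can be sized: a step that the two limits leave unreadable from compound 1 to compound 2, a step that the two limits leave unreadable from compound 1 to compound 3 and a step that the two limits leave unreadable from compound 2 to compound 3 all stay unreadable. Compound 4 `CCOC(=O)c1ccc(-c2nn(Cc3cccc(OC)c3)c3ccccc23)cc1` differs from compound 2 by methoxy in place of chloro on an aromatic carbon. With nothing but limits to build on, compound 4 is expected to sit at the same limit, and the step is expected to stay within the scatter: a step that the limit leaves unreadable from compound 2 to compound 4. The estimate for compound 4 is 20000 nM, with a range from 5000 nM to 80000 nM.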

Compound 4, half-maximal inhibitory concentration: > 10000 nM
Compound 4 gave a limit, no number; the forecaster's own chance of this, stated with the estimate: 85%; the middle value lies beyond the limit too.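

Compound 4, like compounds 1, 2 and 3, gives only a limit and no number, so no step among these four compounds can be read: the limit of > 10000 nM in this assay, at which 4 of the 4 values shown sit.

In this assay the compounds shown leave open how strongly any of them inhibits, and whether any change to the shared core matters.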